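Methylsulfanyl for methoxy on an aromatic carbon

This account rests on a few compounds, and the source may have more. Where it says the series, first, only, none or still open, it means among the compounds named here.

The series is followed in a functional assay on the whole organism (strain Sprague-Dawley) for inhibition, with Rattus norvegicus as the target; a higher number here means that more compound is needed for the effect, a lower number that less compound is needed. Compound 1, `CCc1ccc2c(=O)c(-c3nn[nH]n3)c[nH]c2c1`, gives only a limit there: > 10 mg/kg. For the measured compounds named here, compound 2, `COc1cccc2c(=O)c(-c3nn[nH]n3)c[nH]c12`, is the one compound with a number, giving 0.312 mg/kg in this assay; of the two values shown, it is the only one that is not a limit, the other being described by the limit of > 10 mg/kg in this assay, at which 1 of the 2 values shown sits. Going by the values given here, no pair of measured compounds differs in a single place, so nothing can be said about any step between the two beyond what their values show.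

Compound 3, `CSc1cccc2c(=O)c(-c3nn[nH]n3)c[nH]c12`, has not yet been measured. It differs from compound 2 in one place: methylsulfanyl in place of methoxy on an aromatic carbon.

Among the compounds with values here, for this change no measured example exists, and the expected step is therefore a cautious one. The estimate is that the step of a 1.6-fold higher number from compound 2 to compound 3 (0.20 log units; within the scatter) is small, in either direction, and not clearly beyond the scatter. Compound 3 is accordingly expected to give about 0.5 mg/kg in this assay, within a range from 0.15 mg/kg to 2 mg/kg.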

Compound 3, minimum effective dose: 25 mg/kg
Estimate against measurement, compound 3: 50-fold (1.70 log units) below; the whole stated range lies below it.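

In this assay, the exchange on this aromatic carbon is far from neutral: an 80-fold higher number from compound 2 to compound 3 (1.90 log units; beyond the scatter). For the compounds shown here, this is the first step that can be read, and it shows that the number at this place responds strongly to which atom links the methyl group to the ring, at least for this one pair. Methoxy and methylsulfanyl have the same counts of heavy atoms, hydrogen-bond donors and hydrogen-bond acceptors, and neither carries a net charge, so these counts do not separate compound 2 from compound 3, and nothing measured here accounts for the large step.

A single step on a single pair leaves open whether the low number of compound 2 is particular to methoxy or would also hold for other groups at this place, such as ethoxy, an amine or a chlorine atom. On these data alone, it also remains open how far the same exchange would carry over to other compounds, since compound 1 differs from the others in more than one place and offers no such comparison.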